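Swapping the Para Substituent Again: From Ester to Trifluoromethyl

The source may hold more compounds than are shown below. What is called first, only, known or untested is meant among the compounds shown, and "the series" means these compounds.

Of the compounds shown here, three share a common core and have been tested in a functional assay on A549 cells (Homo sapiens) for antiproliferative activity, tested at 1 uM; on this read-out lower numbers stand for less inhibition and higher numbers for more inhibition at the one concentration tested (going by the name of the read-out). Compound 1 `Cc1c(CO/N=C/c2c(-c3ccccc3)nn(-c3ccccc3)c2Oc2ccc(Cl)cc2)cccc1-c1ccccc1` gives -10.1%, compound 2 `Cc1ccc(CO/N=C/c2c(C)nn(C)c2Oc2ccc(Cl)cc2)cc1` gives 50%, and compound 3 `CCOC(=O)c1ccc(CO/N=C/c2c(C)nn(C)c2Oc2ccc(Cl)cc2)cc1` gives 48.2%. Compound 3 therefore stands second highest of the three numbers, with compound 2 sitting closest and compound 1 furthest away, beyond the scatter.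

The new compound 4 `Cc1nn(C)c(Oc2ccc(Cl)cc2)c1/C=N/OCc1ccc(C(F)(F)F)cc1` differs from compound 3 in one place: trifluoromethyl in place of ethoxycarbonyl on an aromatic carbon. Among the compounds with values here, the only measured step at this position is a number 1.8 percentage points lower from compound 2 to compound 3 (within the scatter), in which one para substituent replaced another without moving the read-out beyond the scatter. Within the data shown here, no measured step covers the trifluoromethyl group itself, so the expectation rests on that single comparison alone.

On this basis compound 4 is expected to stay close to compound 3 in this assay, with a step of a number 0.2 percentage points lower from compound 3 to compound 4 (within the scatter) that lies within the scatter. The estimated value for compound 4 is 48%, with a range from 30% to 65%.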

Compound 4, a percentage reported as inhibition, at one concentration (the size of the read-out at that concentration, not a potency): 50.9%
For compound 4 the middle estimate is 2.9 percentage points below the measured one; the range from low to high includes it.
By their numbers in this assay, from the lowest: compound 1; then compounds 3, 2 and 4 (each within the scatter of the next).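

In this assay this position, para to a large group, now holds a third group with no clear shift in the read-out: trifluoromethyl gives a number 2.7 percentage points higher from compound 3 to compound 4 (within the scatter) in place of ethoxycarbonyl and a number 0.9 percentage points higher from compound 2 to compound 4 (within the scatter) in place of methyl. Ethoxycarbonyl has hydrogen-bond acceptors and trifluoromethyl has none, yet compounds 2, 3 and 4 cannot be told apart on this measurement. No evidence at hand explains why these three groups read alike.

On these data alone, whether an amine, a carboxylic acid or a longer chain at this position would also leave the number in the same range stays open. Also open, as far as these compounds go, is whether this holds on another core such as that of compound 1, which gives -10.1% but differs from the others in more than one place.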